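A Sulfonamide Chain Cut Back to an Alcohol

The compounds below may be only part of what the source reports. "The series", "measured", "known", "first", "only" and "open" are said of these compounds alone.

Measured compounds:
- compound 1, `CC(C)(C)c1cc(C(=O)Nc2nc(CNS(C)(=O)=O)cs2)n(Cc2ccccc2)n1`, with 3.1 ug/mL
- compound 2, `NCc1csc(NC(=O)c2cccnn2)n1`, with > 100 ug/mL

In a physicochemical assay for solubility, read by nephelometry, measured as kinetic solubility, at pH 2.0 (a higher number here means a more soluble compound, a lower number a less soluble compound), compound 1 gives 3.1 ug/mL. Going by the values given here, this is the only plain number in the set. Compound 2 gives > 100 ug/mL in this assay, which is a limit of the assay and not a number. That limit, (the limit of > 100 ug/mL in this assay, at which 1 of the 2 values shown sits), is where one of the two values sits. Compound 2 shares no single-point difference with compound 1, so its value says only that it dissolved beyond what the assay can report, and nothing about any step.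

Compound 3, `CC(C)(C)c1cc(C(=O)Nc2nc(CO)cs2)n(Cc2ccccc2)n1`, has not yet been measured in this assay. It differs from compound 1 in one place: hydroxy in place of methanesulfonamido on a saturated chain carbon bound to an aromatic carbon. The larger methanesulfonamido group leaves and a single hydroxy enters on a saturated chain carbon bound to an aromatic carbon, with the rest of the compound unchanged.

Among the compounds with values here, no measured pair shows what such a change does here. The step from compound 1 to compound 3 is expected to be small, a 1.6-fold higher number from compound 1 to compound 3 (0.21 log units; within the scatter), and hard to tell from the scatter, leaning slightly toward higher solubility. Compound 3 is estimated at 5 ug/mL, within 1.5 ug/mL to 20 ug/mL.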

Compound 3, solubility: 12.5 ug/mL
Compound 3: middle estimate off by 2.5-fold (0.40 log units), on the low side, within the range that was stated.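

Going by these compounds alone, compound 1 and compound 3 form the first pair here that differs in one place, so a step at this position can now be read. In this assay, changing (methanesulfonamido)methyl to hydroxymethyl gives a 4.0-fold higher number from compound 1 to compound 3 (0.61 log units; beyond the scatter), which shows that the read-out responds to what is carried on this saturated chain carbon bound to an aromatic carbon, and that this change gives a modest step rather than one lost in the scatter. Within the data shown here, nothing measured in the set accounts for why the number moves, since this is a single pair and the only other compound differs from these two in more than one place.

The methanesulfonamido group and the hydroxy group differ in both size and make-up, so this pair cannot separate what each of those differences contributes to the step. A carboxylic acid or a longer chain ending in hydroxy, placed on the same carbon of the shared core, would show whether the step belongs to hydroxy alone or extends to other groups at this position.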